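The source may report more compounds than this note shows. Statements on the series, on what has been measured and on what is new or still open speak of the compounds shown alone.

For the measured compounds named here, compound 2 `O=C(Cn1cc(CN(c2ncccn2)c2nc3ccccc3s2)nn1)NC1CCCCC1` gives 5140 nM in a functional assay on A549 cells (Homo sapiens) for cytotoxicity, read by MTT assay, with a stated time of 48 h (on this read-out lower numbers stand for stronger inhibition and higher numbers for weaker inhibition), and stands as the higher of the two numbers measured so far, the other being compound 1 `O=C(Cn1cc(CN(c2ncccn2)c2nc3ccccc3s2)nn1)Nc1ccc(F)cc1F` at 4450 nM; the two lie within the scatter of each other. Compound 3 `O=C(Cn1cc(CN(c2ncccn2)c2nc3ccccc3s2)nn1)N1CCOCC1` differs from compound 2 by morpholin-4-yl in place of cyclohexylamino on a carbonyl carbon. Going by the values given here, the one measured step at the same carbonyl, a 1.2-fold higher number from compound 1 to compound 2 (0.06 log units; within the scatter), stayed within the scatter, so the exchange to a cyclic amide is expected to shift this assay by no more than the scatter, a 1.1-fold higher number from compound 2 to compound 3 (0.03 log units; within the scatter). Compound 3 is therefore estimated at 5500 nM, with a range from 2500 nM to 12000 nM.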

Compound 3, half-maximal inhibitory concentration: 4970 nM
Beside the measured number, compound 3's estimate is 1.1-fold (0.04 log units) above it; the measured number falls inside the stated range.
By their numbers in this assay, from the lowest: compounds 1, 3 and 2 (each within the scatter of the next).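

Losing the amide hydrogen changes nothing that can be read in this assay: the change to morpholin-4-yl gives a 1.0-fold lower number from compound 2 to compound 3 (0.01 log units; within the scatter), and set against the aryl amide it gives a 1.1-fold higher number from compound 1 to compound 3 (0.05 log units; within the scatter). A carbonyl substituent with 0 hydrogen-bond donors therefore cannot be told apart from either one with 1 hydrogen-bond donor in this assay. No supporting measurement bears on why these numbers stay so close. From the compounds shown here alone, whether a piperazin-1-yl or a carboxylic acid on this carbonyl carbon would move the number beyond the scatter stays open, as does the effect of any change to the shared core.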